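This account rests on a few compounds, and the source may have more. Where it says the series, first, only, none or still open, it means among the compounds named here.

Measured in a functional assay on CHO cells with adenosine receptor A1 (Homo sapiens) as the target, read by cAMP accumulation and immunoassay, with a stated time of 6 min, tested at 0.01 uM; on this read-out higher numbers stand for a weaker effect at the one concentration tested and lower numbers for a stronger effect:
Compound 1 `Nc1scc(CN2CCN(c3cccc(Cl)c3Cl)CC2)c1C(=O)c1ccc(Cl)cc1` gives 1%.
Compound 2 `Nc1scc(CN2CCN(c3ccncc3)CC2)c1C(=O)c1ccc(Cl)cc1` gives -4%.
Compound 3 `Nc1scc(CN2CCN(c3cccc(F)c3)CC2)c1C(=O)c1ccc(Cl)cc1` gives -18%.

Compound 3 stands lowest of the three numbers in this assay, and both of its steps to the others lie beyond the scatter: a number 19 percentage points lower from compound 1 to compound 3 (beyond the scatter) and a number 14 percentage points lower from compound 2 to compound 3 (beyond the scatter), whereas a number 5 percentage points lower from compound 1 to compound 2 (within the scatter). Compound 4 `Nc1scc(CN2CCN(c3c(F)cccc3F)CC2)c1C(=O)c1ccc(Cl)cc1` differs from compound 3 by 2,6-difluorophenyl in place of 3-fluorophenyl on an amine nitrogen in a ring. Among the measured compounds shown here, no measured step alters only the fluorine count on this ring; the two steps that lead into compound 3 each exchange the whole aryl group and were modest in size. The present change is smaller than either, so no movement beyond the scatter is expected in this assay, with a number 6 percentage points higher from compound 3 to compound 4 (within the scatter) as the expected step. Compound 4 is estimated at -12%, range -30% to 6%.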

Compound 4, a percentage reported as activity, at one concentration (the size of the read-out at that concentration, not a potency): -12%
Compound 4: middle estimate and measured number agree at the digits printed; the measured number falls inside the stated range.
By their numbers in this assay, from the lowest: compounds 3, 4, 2 and 1 (each within the scatter of the next, the first and the last beyond it).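

In this assay the exchange of 3-fluorophenyl for 2,6-difluorophenyl on the amine nitrogen gives a number 6 percentage points higher from compound 3 to compound 4 (within the scatter) and the exchange of pyridin-4-yl for the same group gives a number 8 percentage points lower from compound 2 to compound 4 (within the scatter) so at this position a second fluorine brings no change that can be told from the scatter. Against 2,3-dichlorophenyl the new group gives a number 13 percentage points lower from compound 1 to compound 4 (beyond the scatter) so compound 3 and compound 4, the two fluorinated compounds, both lie apart from the dichlorinated compound 1. No measurement at hand explains these steps. On these data alone, what a methoxy group or a carboxylic acid on this aryl ring would do stays open, as does the effect of a single chlorine in place of the two in compound 1.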